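Hydroxy to Amino Swap Carried onto a Second Core

This account rests on a few compounds, and the source may have more. Where it says the series, first, only, none or still open, it means among the compounds named here.

In an assay for inhibition of S-adenosylmethionine decarboxylase proenzyme (Rattus norvegicus) (on this read-out lower numbers stand for stronger inhibition and higher numbers for weaker inhibition), compound 1, `N=C(NO)N/N=C/c1cccc(C(=N)N)c1`, gives 92 nM.
Compound 2, `N=C(NN)N/N=C/c1cccc(C(=N)N)c1`, gives 210 nM.
Compound 3, `N=C(NO)N/N=C/c1cccc(C(=N)N)n1`, gives 240 nM.

One change is seen twice here. Between compound 1 and compound 2 it is amino in place of hydroxy on an amine nitrogen, and it produced a 2.3-fold higher number from compound 1 to compound 2 (0.36 log units; beyond the scatter). Compound 4, `N=C(NN)N/N=C/c1cccc(C(=N)N)n1`, is not yet measured; it arises from compound 3 by amino in place of hydroxy on an amine nitrogen, at a place described in the same words, so this is the same change on a different core. The difference between the cores of compound 1 and compound 3 is not broken down here. Compound 3 stands highest of the three measured numbers, close to compound 2 and well apart from compound 1.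

Going by the values given here, for compound 4 the step is expected to be a 2.2-fold higher number from compound 3 to compound 4 (0.34 log units; beyond the scatter), resting on the single earlier step of a 2.3-fold higher number from compound 1 to compound 2 (0.36 log units; beyond the scatter), with no second example to confirm it. Compound 4 is therefore estimated at 520 nM, between 200 nM and 1300 nM.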

Compound 4, half-maximal inhibitory concentration: 670 nM
Estimate against measurement, compound 4: 1.3-fold (0.11 log units) below; the range from low to high includes it.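

In this assay, amino in place of hydroxy on an amine nitrogen gave a 2.8-fold higher number from compound 3 to compound 4 (0.45 log units; beyond the scatter), so the number rose on the second core as it had on the first. The two steps do not differ in size beyond what repeated measurements would allow: the same change on two cores in this assay, a 2.3-fold higher number (0.36 log units; beyond the scatter) from compound 1 to compound 2 and a 2.8-fold higher number (0.45 log units; beyond the scatter) from compound 3 to compound 4, 1.2-fold (0.09 log units) apart, within the scatter of two such steps. This shows that the change carried across these two cores, but with one pair on each core it does not show that it would carry to any further core, and it does not explain why the steps agree.

The compounds shown leave open what other groups on that nitrogen would do, such as methyl or methoxy in place of hydroxy. They also leave open whether the step would hold with an amine or a carboxylic acid in place of the amidine.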